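A hexylsulfanyl analogue in a cytotoxicity series

This account rests on a few compounds, and the source may have more. Where it says the series, first, only, none or still open, it means among the compounds named here.

Compound 2 `CN(C)c1nc(N)nc2c1ncn2/C=C1/CC1(CO)CO` shares its core with compound 1 `CCOc1nc(N)nc2c1ncn2/C=C1/CC1(CO)CO` and compound 3 `Nc1nc2c(ncn2/C=C2/CC2(CO)CO)c(=O)[nH]1`, and all three were tested for tolerability in an ADME assay on CCRF-HSB-2 cells (Homo sapiens) for cytotoxicity, with a stated time of 7 days; a lower number here means that less compound is tolerated, a higher number that more compound is tolerated. In this assay compound 2 gives only a limit, > 20000 nM. Compound 1 likewise yields a limit in this assay, > 20000 nM. Compound 3 too reaches only a limit, > 20000 nM. The step that the two limits leave unreadable from compound 1 to compound 2 runs between two limits and cannot be read; the limit of > 20000 nM in this assay, at which 3 of the 3 values shown sit, marks where all three values sit. Compound 4 `CCCCCCSc1nc(N)nc2c1ncn2/C=C1/CC1(CO)CO` differs from compound 2 by hexylsulfanyl in place of dimethylamino on an aromatic carbon. Among the compounds with values here, no measured step touches a hexylsulfanyl group, and none of the three measured values is a number, so no size of step can be carried over from the series. Compound 4 is therefore expected to remain near the limit, and the step that the limit leaves unreadable from compound 2 to compound 4 is expected to lie within the scatter. The estimate for compound 4 in this assay is 25000 nM, between 8000 nM and 80000 nM.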

Compound 4, half-maximal cytotoxic concentration: 60000 nM
Compound 4: the middle estimate sits 2.4-fold (0.38 log units) below what was measured, and the stated range covers the measured number.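

Compound 4 gives a number in this assay, but the steps to it from compound 1 and compound 2 cannot be read, because those two compounds give only a limit: the limit of > 20000 nM in this assay, at which 3 of the 4 values shown sit.

The compounds shown leave open how large any difference among the ethoxy, dimethylamino and hexylsulfanyl compounds is.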